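The source may report more compounds than this note shows. Statements on the series, on what has been measured and on what is new or still open speak of the compounds shown alone.

Going by the values given here, compound 1 `Cc1nc(SCC(=O)Nc2nc(-c3ccc(Cl)cc3)cs2)n(Nc2ccccc2)c1C`, tested in a functional assay on OVCAR-8 cells (Homo sapiens) for antiproliferative activity, read by sulforhodamine B assay, with a stated time of 48 h (a lower number here means a stronger inhibitor of growth, a higher number a weaker inhibitor of growth), gives 2710 nM, the lower of the two numbers measured so far. Compound 2 `Cc1ccc(Nn2c(SCC(=O)Nc3nc(-c4ccccc4)cs3)nc(C)c2C)cc1` differs from compound 1 in two places; in this assay compound 2 gives 3790 nM, and the two values lie within the scatter of each other. Compound 3 `COc1ccc(Nn2c(SCC(=O)Nc3nc(-c4ccc(Cl)cc4)cs3)nc(C)c2C)cc1` differs from compound 1 in one place: methoxy in place of hydrogen on an aromatic carbon. Among the compounds with values here, no measured pair shows this change alone, so no step beyond the scatter is expected in either direction in this assay. The expected step is a 1.1-fold lower number from compound 1 to compound 3 (0.04 log units; within the scatter). Compound 3 is accordingly estimated to give 2500 nM, within a range from 1000 nM to 6500 nM, in this assay.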

Compound 3, concentration for 50% growth inhibition: 4820 nM
For compound 3 the middle estimate is 1.9-fold (0.29 log units) below the measured one; low and high end bracket the measured number.
By their numbers in this assay, from the lowest: compounds 1, 2 and 3 (each within the scatter of the next).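

In this assay, methoxy in place of hydrogen on an aromatic carbon, para to a large group, gives a 1.8-fold higher number from compound 1 to compound 3 (0.25 log units; within the scatter) and so leaves compound 1 and compound 3 indistinguishable. This is the first change in a single place among the compounds shown, and it indicates that this carbon of the anilino ring accepts methoxy with no step beyond the scatter. No evidence at hand bears on this result.
On these data alone, whether an amine or a carboxylic acid on this carbon would separate from compound 1 stays open. The same holds for a longer chain such as butoxy.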